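From Hydroxyethyl to Benzyl on the Shared Core

The source may hold more compounds than are shown below. What is called first, only, known or untested is meant among the compounds shown, and "the series" means these compounds.

Of the compounds shown here, two built on one shared core have been measured in a functional assay on HeLa cells (Homo sapiens) for antiproliferative activity, read by sulforhodamine B assay; a lower number here means a stronger inhibitor of growth, a higher number a weaker inhibitor of growth. Compound 1 `CC[C@@H]1O[C@H](COCc2ccccc2)[C@@H](OCc2ccccc2)[C@H](OCc2ccccc2)[C@H]1O` gives 19800 nM in this assay, and compound 2 `OCC[C@@H]1O[C@H](COCc2ccccc2)[C@@H](OCc2ccccc2)[C@H](OCc2ccccc2)[C@H]1O` gives 30200 nM. Compound 2 thus carries the higher of the two numbers, but the step of a 1.5-fold higher number from compound 1 to compound 2 (0.18 log units; within the scatter) is within the scatter, so the two compounds stand level rather than apart.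

Compound 3 `O[C@@H]1[C@@H](OCc2ccccc2)[C@H](OCc2ccccc2)[C@@H](COCc2ccccc2)O[C@H]1Cc1ccccc1` has not yet been measured in this assay. It differs from compound 2 by phenyl in place of hydroxymethyl on a saturated chain carbon bound to a saturated ring carbon. Among the compounds with values here, the only measured step concerns a hydroxy added to the chain and amounts to a 1.5-fold higher number from compound 1 to compound 2 (0.18 log units; within the scatter); it touches the same chain but not the exchange of hydroxymethyl for phenyl, so it gives only weak guidance. On this slender basis, compound 3 is expected to show a step of a 1.5-fold lower number from compound 2 to compound 3 (0.18 log units; within the scatter), not beyond the scatter. The estimate for compound 3 is therefore 20000 nM, with a range from 6000 nM to 60000 nM.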

Compound 3, concentration for 50% growth inhibition: 17400 nM
Beside the measured number, compound 3's estimate is 1.1-fold (0.06 log units) above it; low and high end bracket the measured number.
By their numbers in this assay, from the lowest: compounds 3, 1 and 2 (each within the scatter of the next).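

In this assay, phenyl in place of hydroxymethyl on a saturated chain carbon bound to a saturated ring carbon leaves compound 3 level with compound 2 (a 1.7-fold lower number from compound 2 to compound 3 (0.24 log units; within the scatter)), and phenyl in place of methyl at that place leaves it level with compound 1 (a 1.1-fold lower number from compound 1 to compound 3 (0.06 log units; within the scatter)). The earlier pair had tested only a hydroxy on the chain, whereas these steps show that an aromatic ring of six carbons can stand at this position, with six heavy atoms entering where two leave, and the number stays within the scatter. Nothing at hand offers an explanation for this level result.

As far as these compounds go, whether an amine, a carboxylic acid or a longer chain at this place would move the number beyond the scatter remains open. So does the effect of a pyridine ring or of a chloro group on the phenyl.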